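The source may hold more compounds than are shown below. What is called first, only, known or untested is meant among the compounds shown, and "the series" means these compounds.

Compound 1, `O=C1NC(=O)/C(=C/c2ccc(OC(=O)c3cccs3)c(Cl)c2)S1`, and compound 2, `O=C1NC(=O)/C(=C/c2ccc(OCCOC3CCCCC3)c(Cl)c2)S1`, share one core and differ only in the group attached through the oxygen on the aromatic ring. In an assay for inhibition of 15-hydroxyprostaglandin dehydrogenase [NAD(+)] (Homo sapiens), read by fluorescence and spectrophotometry (on this read-out lower numbers stand for stronger inhibition and higher numbers for weaker inhibition), compound 1 gives 264 nM, while compound 2 gives 20 nM, the lower of the two numbers and the stronger inhibition; the gap between them lies beyond the usual scatter.

Compound 3, `O=C1NC(=O)/C(=C/c2ccc(OCC3CCCC3)c(Cl)c2)S1`, has not yet been measured. It differs from compound 2 in one place: cyclopentyl in place of (cyclohexyloxy)methyl on a saturated chain carbon bound to an oxygen on an aromatic ring. Among the measured compounds shown here, no measured pair shows this kind of exchange, so the size of the step is open. Because compound 2 already gives 20 nM, the expectation is a small step toward higher numbers, a 2.0-fold higher number from compound 2 to compound 3 (0.30 log units; within the scatter), likely within the scatter. Compound 3 is therefore estimated at 40 nM, with a range from 10 nM to 200 nM.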

Compound 3, half-maximal inhibitory concentration: 11 nM
Compound 3: middle estimate off by 3.6-fold (0.56 log units), on the high side; measured number inside the range.
By their numbers in this assay, from the lowest: compounds 3 and 2 (each within the scatter of the next); then compound 1.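

In this assay, cyclopentyl in place of (cyclohexyloxy)methyl gives a 1.8-fold lower number from compound 2 to compound 3 (0.26 log units; within the scatter), so this place accepts either group without a measurable difference, even though the group that enters has fewer heavy atoms, a five-membered rather than a six-membered ring, and no hydrogen-bond acceptor. Among the compounds shown here, the exchange of (thiophen-2-yl)carbonyl for cyclopentylmethyl on the oxygen on the aromatic ring gives a 24-fold lower number from compound 1 to compound 3 (1.38 log units; beyond the scatter), a large step that now holds for a group much smaller than the one in compound 2. Nothing available explains these numbers.

The compounds shown leave open whether a ring is needed at this place at all, or whether a plain longer chain would serve as well. As far as these compounds go, how an amine or a carboxylic acid at the end of the chain would fare also remains open.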